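The compounds below may be only part of what the source reports. "The series", "measured", "known", "first", "only" and "open" are said of these compounds alone.

Three compounds share one core and differ only in the group on one aromatic carbon: compound 1 `Nc1nc(OCC(F)(F)F)c2ncn(/C=C3/CC3(CO)CO)c2n1`, compound 2 `CCCNc1nc(N)nc2c1ncn2/C=C1/CC1(CO)CO` and compound 3 `CCCCCCCCSc1nc(N)nc2c1ncn2/C=C1/CC1(CO)CO`. In an ADME assay on HFF cells (Homo sapiens) for cytotoxicity, with a stated time of 8 days (on this read-out lower numbers stand for higher toxicity in this test and higher numbers for lower toxicity in this test), compound 1 reached only the limit > 300000 nM. Compound 2 likewise gave only the limit > 300000 nM. Compound 3 also stopped at the limit > 300000 nM. All three values rest at the limit of > 300000 nM in this assay, at which 3 of the 3 values shown sit, so the steps a step that the two limits leave unreadable from compound 1 to compound 3, a step that the two limits leave unreadable from compound 2 to compound 3 and a step that the two limits leave unreadable from compound 1 to compound 2 give no size to carry forward. Compound 4 `CCCCSc1nc(N)nc2c1ncn2/C=C1/CC1(CO)CO` differs from compound 3 by hydrogen in place of butyl on a saturated chain carbon, four bonds along the chain from a sulfur. For the measured compounds named here, with every measured value a limit, no measured step shows whether this change matters, and compound 4 is expected to stop at a limit as well. The expected step that the limit leaves unreadable from compound 3 to compound 4 is therefore none beyond the scatter. Compound 4 is estimated at 400000 nM, between 150000 nM and 1500000 nM.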

Compound 4, half-maximal cytotoxic concentration: > 300000 nM
Compound 4: only a limit was reported; the forecaster's own chance of this, stated with the estimate: 90%; the middle value is on the limit's open side.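

In this assay compound 4 also gave only a limit, so its steps from compound 1, compound 2 and compound 3 cannot be read: the limit of > 300000 nM in this assay, at which 4 of the 4 values shown sit. The compounds shown leave open whether the group on that aromatic carbon changes the read-out at all.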